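The source may hold more compounds than are shown below. What is called first, only, known or untested is meant among the compounds shown, and "the series" means these compounds.

In a functional assay on HL-60 cells (Homo sapiens) for antiproliferative activity, read by sulforhodamine B assay, with a stated time of 72 h (on this read-out higher numbers stand for weaker inhibition and lower numbers for stronger inhibition), compound 3 (`Cc1ccccc1NC(=S)N/N=C/c1ccc2ccccc2n1`) gives 73200 nM. Among the measured compounds shown here, the only other number belongs to compound 2 (`S=C(N/N=C/c1ccc2ccccc2n1)Nc1cccc(Br)c1`), which gives 53800 nM. The two lie within the scatter of each other, as a 1.4-fold higher number from compound 2 to compound 3 (0.13 log units; within the scatter) shows. Compound 1 (`Cc1cccc(NC(=S)N/N=C/c2ccc3ccccc3n2)c1`) gives only a limit, > 100000 nM.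

The next compound, compound 4 (`S=C(N/N=C/c1ccc2ccccc2n1)Nc1ccc(Br)cc1`), carries 4-bromophenyl in place of 2-methylphenyl on an amide-type nitrogen whose other neighbour is the thiocarbonyl carbon: 4-bromophenyl in place of 2-methylphenyl on an amide-type nitrogen. For the measured compounds named here, three measured steps bear on this change. The closest is the step between compound 2 and compound 3 already given, since compound 2 carries 3-bromophenyl on that same nitrogen. The other two start from the limit of compound 1: an at least 1.8-fold lower number from compound 1 to compound 2 (0.26 log units; that floor lies within the scatter) exchanges methyl for bromo, and an at least 1.3-fold lower number from compound 1 to compound 3 (0.13 log units; that floor lies within the scatter) exchanges one methylphenyl for another. Neither floor goes beyond the scatter, so none of the three steps shows a change of aryl group on this nitrogen moving the number by more than the scatter. No step beyond the scatter is therefore expected in this assay, and no direction is favoured. The expected result is a 1.3-fold lower number from compound 3 to compound 4 (0.12 log units; within the scatter). Compound 4 is estimated at 55000 nM, with an expected range from 18000 nM to 100000 nM.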

Compound 4, half-maximal inhibitory concentration: 27500 nM
Compound 4: the middle estimate sits 2.0-fold (0.30 log units) above what was measured; measured number inside the range.
By their numbers in this assay, from the lowest: compounds 4, 2 and 3 (each within the scatter of the next, the first and the last beyond it). At a limit, above all of these: compound 1.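

In this assay, this amide-type nitrogen now shows a change of aryl group that goes beyond the scatter, which no earlier step had shown: 4-bromophenyl in place of 2-methylphenyl gives a 2.7-fold lower number from compound 3 to compound 4 (0.43 log units; beyond the scatter) and so marks the first clear separation in the series. The bromo isomers do not separate in the same way, as 4-bromophenyl in place of 3-bromophenyl gives a 2.0-fold lower number from compound 2 to compound 4 (0.29 log units; within the scatter) and thus stays within the scatter, so the gain over compound 3 cannot be tied to the 4-bromophenyl group alone. The step of an at least 3.6-fold lower number from compound 1 to compound 4 (0.56 log units; beyond the scatter) also passes the scatter, but it is only a floor, since compound 1 stands at a limit of the assay: the limit of > 100000 nM in this assay, at which 1 of the 4 values shown sits.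

Compound 3 and compound 4 differ in both the substituent and its place on the ring, so the compounds shown leave open how 4-methylphenyl on this nitrogen would read against 4-bromophenyl. They also leave open how an unsubstituted phenyl, 4-chlorophenyl or 4-methoxyphenyl group would read on the same nitrogen.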